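A few compounds are considered here, and "the series" means these few. Any claim that something is new, unique, unknown or untested is made for them only; others in the source may bear on it.

Of the compounds shown here, three have been measured. Compound 1, `Cc1cc(=O)n(-c2ccc(Br)cc2F)nc1C(=O)Nc1ccc(Oc2ncnc3ccsc23)cc1`, gives 7930 nM in a functional assay on A549 cells (Homo sapiens) for cytotoxicity, read by MTT assay, with a stated time of 72 h; a higher number here means a weaker inhibitor, a lower number a stronger inhibitor. Compound 2, `Cc1cc(=O)n(-c2ccccc2OC(F)(F)F)nc1C(=O)Nc1ccc(Oc2ncnc3ccsc23)cc1`, gives 10100 nM. Compound 3, `Cc1cc(=O)n(-c2ccc(Br)cc2F)nc1C(=O)Nc1ccc(Oc2ncnc3sccc23)c(F)c1`, gives 11500 nM.

Compound 1 and compound 2 share a core and differ in one place: 2-(trifluoromethoxy)phenyl in place of 4-bromo-2-fluorophenyl on an aromatic nitrogen. That change produced a 1.3-fold higher number from compound 1 to compound 2 (0.11 log units; within the scatter). Compound 3 rests on a different core; how its core differs from that of compound 1 is not broken down here. Compound 4, `Cc1cc(=O)n(-c2ccccc2OC(F)(F)F)nc1C(=O)Nc1ccc(Oc2ncnc3sccc23)c(F)c1`, has not yet been measured in this assay. It stands to compound 3 as compound 2 stands to compound 1: 2-(trifluoromethoxy)phenyl in place of 4-bromo-2-fluorophenyl on an aromatic nitrogen, the same change at the same place.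

Because the earlier instance of this change gave a 1.3-fold higher number from compound 1 to compound 2 (0.11 log units; within the scatter), compound 4 is expected to show a 1.3-fold higher number from compound 3 to compound 4 (0.12 log units; within the scatter), a step of about the same size. Compound 4 is therefore estimated at 15000 nM, with a likely range from 7000 nM to 32000 nM.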

Compound 4, half-maximal inhibitory concentration: > 40000 nM
Compound 4: a limit, no number; the forecaster's own chance of this, stated with the estimate: 10%; middle value at least 2.6-fold (0.42 log units) away from the limit.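

Compound 4 gives > 40000 nM in this assay, which is a limit of the assay and not a number. On the core of compound 3, 2-(trifluoromethoxy)phenyl in place of 4-bromo-2-fluorophenyl gives an at least 3.4-fold higher number from compound 3 to compound 4 (0.54 log units; beyond the scatter), so the size of the step did not carry over from the core of compound 1: the same change on two cores in this assay, a 1.3-fold higher number (0.11 log units; within the scatter) from compound 1 to compound 2 and an at least 3.4-fold higher number (0.54 log units; beyond the scatter) from compound 3 to compound 4, at least 2.7-fold (0.43 log units) apart, beyond the scatter of two such steps. The limit leaves the full size of this step unknown, and these two pairs do not show which feature of the cores goes with the difference or how the change would behave on any further core.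

On these data alone, it remains open whether the gap between the two cores would also appear with other groups on the aromatic nitrogen, such as a phenyl ring bearing an amine or a carboxylic acid. Which part of the difference between the two cores matters also stays unresolved.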